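Benzylindole thiosemicarbazone-type ureas on breast cancer cells

The source may report more compounds than this note shows. Statements on the series, on what has been measured and on what is new or still open speak of the compounds shown alone.

Measured compounds:
compound 1 `CC1CCN(Cc2ccc3nc(NC(=O)N/N=C/c4cn(Cc5ccc(Cl)cc5Cl)c5ccccc45)sc3c2)CC1` — 3140 nM
compound 2 `CC1CCN(Cc2ccc3nc(NC(=O)N/N=C/c4cn(Cc5cccc(Cl)c5)c5ccccc45)sc3c2)CC1` — 2110 nM
compound 3 `CCN(CC)Cc1ccc2nc(NC(=O)N/N=C/c3cn(Cc4ccc(Cl)cc4Cl)c4ccccc34)sc2c1` — 3280 nM

Three compounds sharing a common core were measured in a functional assay on MDA-MB-231 cells (Homo sapiens) for cytotoxicity, read by MTT assay, with a stated time of 72 h; on this read-out lower numbers stand for stronger inhibition and higher numbers for weaker inhibition. Compound 1 `CC1CCN(Cc2ccc3nc(NC(=O)N/N=C/c4cn(Cc5ccc(Cl)cc5Cl)c5ccccc45)sc3c2)CC1` gives 3140 nM. Compound 2 `CC1CCN(Cc2ccc3nc(NC(=O)N/N=C/c4cn(Cc5cccc(Cl)c5)c5ccccc45)sc3c2)CC1` differs from it by one change, (3-chlorophenyl in place of 2,4-dichlorophenyl on a saturated chain carbon bound to an aromatic nitrogen), and gives 2110 nM; the step is a 1.5-fold lower number from compound 1 to compound 2 (0.17 log units; within the scatter). Compound 3 `CCN(CC)Cc1ccc2nc(NC(=O)N/N=C/c3cn(Cc4ccc(Cl)cc4Cl)c4ccccc34)sc2c1` carries a different core-side group, (diethylamino in place of 4-methylpiperidin-1-yl on a saturated chain carbon bound to an aromatic carbon), and gives 3280 nM; the step is a 1.0-fold higher number from compound 1 to compound 3 (0.02 log units; within the scatter). All three numbers sit within the scatter of one another, so no order among them can be claimed.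

Compound 4 `CCN(CC)Cc1ccc2nc(NC(=O)N/N=C/c3cn(Cc4cccc(Cl)c4)c4ccccc34)sc2c1` has not yet been measured. It differs from compound 3 by 3-chlorophenyl in place of 2,4-dichlorophenyl on a saturated chain carbon bound to an aromatic nitrogen, which is the same change already seen from compound 1 to compound 2, made here on the core of compound 3. Since the step from compound 1 to compound 3 was a 1.0-fold higher number from compound 1 to compound 3 (0.02 log units; within the scatter), the two cores behaved alike, and the change is expected to carry a similar small step: for compound 4 the expected step is a 1.5-fold lower number from compound 3 to compound 4 (0.17 log units; within the scatter) in this assay. Compound 4 is therefore estimated at 2200 nM, within 1200 nM to 4200 nM.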

Compound 4, half-maximal inhibitory concentration: 2050 nM
Compound 4: middle estimate off by 1.1-fold (0.03 log units), on the high side; low and high end bracket the measured number.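

In this assay, 3-chlorophenyl in place of 2,4-dichlorophenyl gives a 1.6-fold lower number from compound 3 to compound 4 (0.20 log units; within the scatter), and this agrees with the same change on the other core: the same change on two cores in this assay, a 1.5-fold lower number (0.17 log units; within the scatter) from compound 1 to compound 2 and a 1.6-fold lower number (0.20 log units; within the scatter) from compound 3 to compound 4, 1.1-fold (0.03 log units) apart, within the scatter of two such steps. Diethylamino in place of 4-methylpiperidin-1-yl gives a 1.0-fold lower number from compound 2 to compound 4 (0.01 log units; within the scatter), and this change also reads alike in both settings: the same change on two cores in this assay, a 1.0-fold higher number (0.02 log units; within the scatter) from compound 1 to compound 3 and a 1.0-fold lower number (0.01 log units; within the scatter) from compound 2 to compound 4, 1.1-fold (0.03 log units) apart, within the scatter of two such steps. The four compounds thus show that, in this small set, each change behaves the same way on both cores, but since every step lies within the scatter, they do not show that either change alters the number at all, nor that such transfer would hold beyond these two pairs.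

The compounds shown leave open whether a step beyond the scatter can be reached at either place in the series. A morpholine or piperazine in place of the two amines, or an unsubstituted benzyl or a fluorobenzyl in place of the chlorinated benzyl groups, might answer that and would test whether the two changes stay independent.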